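The compounds below may be only part of what the source reports. "The series", "measured", "known", "first", "only" and "open" are said of these compounds alone.

In a functional assay (muscle tissue) with Cavia porcellus as the target (a lower number here means that less compound is needed, a higher number that more compound is needed for the effect), compound 2 `COC(=O)C1=C(C)N=C(C)/C(=C(\O)OC)C1c1cccc(C)c1` gives 110 nM, the middle of three measured numbers: compound 1 `COC(=O)C1=C(C)N=C(C)/C(=C(\O)OC)C1c1ccccc1N` gives 39800 nM and compound 3 `C=Cc1ccccc1C1C(C(=O)OC)=C(C)N=C(C)/C1=C(\O)OC` gives 4.47 nM. Compound 4 `COC(=O)C1=C(C)N=C(C)/C(=C(\O)OC)C1c1cccc(OC(=O)c2ccccc2)c1` differs from compound 2 at one place: benzoyloxy in place of methyl on an aromatic carbon. Two measured steps changed the group on the aromatic ring: a 360-fold lower number from compound 1 to compound 2 (2.56 log units; beyond the scatter) and a 25-fold lower number from compound 2 to compound 3 (1.39 log units; beyond the scatter), both large. Neither involves benzoyloxy, so they show that this part of the molecule can move the number strongly, but they do not fix the direction for compound 4. In this assay, the expected change is moderate, tentatively toward a higher number: a 4.5-fold higher number from compound 2 to compound 4 (0.66 log units; beyond the scatter). For compound 4, the estimated value is 500 nM, with an expected range from 80 nM to 3000 nM.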

Compound 4, half-maximal effective concentration: 6310 nM
The estimate for compound 4 lay 13-fold (1.10 log units) below the measured number; the whole stated range lies below it.
By their numbers in this assay, from the lowest: compound 3; then compound 2; then compound 4; then compound 1.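

In this assay, benzoyloxy in place of methyl on this aromatic carbon gives a 57-fold higher number from compound 2 to compound 4 (1.76 log units; beyond the scatter), a large move toward needing more compound. The earlier steps shown here involved only small groups, whereas this one shows that a far larger group, bringing a second aromatic ring, goes with a much higher number at this place. No measurement shown here explains this rise. On these data alone, it remains open whether the added ring or the linking oxygen and carbonyl accounts for the step. A hydroxy or methoxy group here, or a benzyl group, would help separate the two.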